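The source may report more compounds than this note shows. Statements on the series, on what has been measured and on what is new or still open speak of the compounds shown alone.

Compound 1 `CCN(CC)CCn1c(N)c(-c2nc3ccccc3[nH]2)c2nc(C#N)c(C#N)nc21` gives 7150 nM in a functional assay on HL60/MX2 cells (Homo sapiens) for antiproliferative activity, read by MTT assay, with a stated time of 48 h (on this read-out higher numbers stand for weaker inhibition and lower numbers for stronger inhibition), the highest of the two numbers recorded, with compound 3 `N#Cc1nc2c(-c3nc4ccccc4[nH]3)c(N)n(CCCN3CCCCC3)c2nc1C#N` nearest at 1010 nM. Compound 2 `N#Cc1nc2c(-c3nc4ccccc4[nH]3)c(N)n(CCO)c2nc1C#N` reaches only the limit of > 50000 nM in this assay. Compound 4 `CCN(CC)CCCCn1c(N)c(-c2nc3ccccc3[nH]2)c2nc(C#N)c(C#N)nc21` differs from compound 1 by 2-(diethylamino)ethyl in place of diethylamino on a saturated chain carbon, two bonds along the chain from an aromatic nitrogen. Within the data shown here, two measured steps bear on this change: the step that also lengthens the chain while keeping a diethylamino-like end gave a 7.1-fold lower number from compound 1 to compound 3 (0.85 log units; beyond the scatter), whereas the step that removes the diethylamino for hydroxy gave an at least 6.9-fold higher number from compound 1 to compound 2 (0.84 log units; beyond the scatter). Since compound 4 keeps the diethylamino and only lengthens the chain, a modest step to a lower number is expected, a 2.9-fold lower number from compound 1 to compound 4 (0.46 log units; beyond the scatter). Compound 4 is therefore estimated at 2500 nM, between 800 nM and 8000 nM.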

Compound 4, half-maximal inhibitory concentration: 1550 nM
For compound 4 the middle estimate is 1.6-fold (0.21 log units) above the measured one; the range from low to high includes it.
By their numbers in this assay, from the lowest: compounds 3 and 4 (each within the scatter of the next); then compound 1. At a limit, above all of these: compound 2.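

In this assay, the 4-(diethylamino)butyl chain in place of the 2-(diethylamino)ethyl chain gives a 4.6-fold lower number from compound 1 to compound 4 (0.66 log units; beyond the scatter), so the chain alone moves the number while the diethylamino end stays the same. The piperidin-1-yl end and the diethylamino end on chains of this kind cannot be told apart here, with a 1.5-fold higher number from compound 3 to compound 4 (0.19 log units; within the scatter). The hydroxy compound stays far off, with an at least 32-fold lower number from compound 2 to compound 4 (1.50 log units; beyond the scatter), and this step rests on a limit for compound 2: the limit of > 50000 nM in this assay, at which 1 of the 4 values shown sits.

The compounds shown leave open whether a longer chain, such as 5-(diethylamino)pentyl, would lower the number further. They also leave open how a morpholine end would compare.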